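This account rests on a few compounds, and the source may have more. Where it says the series, first, only, none or still open, it means among the compounds named here.

In a functional assay on MCF7 cells (Homo sapiens) for antiproliferative activity, read by MTT assay, with a stated time of 48 h (on this read-out higher numbers stand for weaker inhibition and lower numbers for stronger inhibition), three compounds sharing one core have been measured. Compound 1 (`CC(C)=CCC[C@]1(C)/C=C/[C@@H](OC(=O)C=C(C)C)[C@](C)(O)/C=C/C(=O)/C(CF)=C\C1`) gives 240 nM, compound 2 (`CC(=O)OC/C1=C/C[C@](C)(CCC=C(C)C)/C=C/[C@@H](OC(=O)C=C(C)C)[C@](C)(O)/C=C/C1=O`) gives 4510 nM, and compound 3 (`CC[Si](CC)(CC)C/C1=C/C[C@](C)(CCC=C(C)C)/C=C/[C@@H](OC(=O)C=C(C)C)[C@](C)(O)/C=C/C1=O`) gives 3150 nM. Compound 3 therefore lies close to one neighbour and far from the other: the data show a 1.4-fold lower number from compound 2 to compound 3 (0.16 log units; within the scatter), which is within the scatter, against a 13-fold higher number from compound 1 to compound 3 (1.12 log units; beyond the scatter), which is beyond it. Acetoxy in place of fluoro produced a similarly large step, a 19-fold higher number from compound 1 to compound 2 (1.27 log units; beyond the scatter).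

Compound 4 (`CCN(CC)C(=O)/C1=C/C[C@](C)(CCC=C(C)C)/C=C/[C@@H](OC(=O)C=C(C)C)[C@](C)(O)/C=C/C1=O`) differs from compound 3 by a group of 7 heavy atoms (5 carbon, 1 nitrogen, 1 oxygen; no ring) in place of a group of 8 heavy atoms (7 carbon, 1 silicon; no ring), on a double-bonded ring carbon. The entering group is diethylcarbamoyl, and it sits on a double-bonded ring carbon of the non-aromatic ring. For the measured compounds named here, no measured step makes this exchange, and no measured compound carries diethylcarbamoyl, so the evidence is indirect. The closest guide is the exchange of one larger group for another, a 1.4-fold lower number from compound 2 to compound 3 (0.16 log units; within the scatter), which stayed within the scatter. The large steps both start from the fluorine-bearing compound 1, and compound 4 has no fluorine atom. In this assay, no step beyond the scatter is therefore expected, and the expected change is a 1.1-fold lower number from compound 3 to compound 4 (0.02 log units; within the scatter). Compound 4 is estimated at 3000 nM, with an expected range from 800 nM to 10000 nM.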

Compound 4, half-maximal inhibitory concentration: 12100 nM
For compound 4 the middle estimate is 4.0-fold (0.61 log units) below the measured one; measured number above the stated range.
By their numbers in this assay, from the lowest: compound 1; then compounds 3 and 2 (each within the scatter of the next); then compound 4.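

In this assay, the double-bonded ring carbon proves not to be indifferent to which larger group it carries: the exchange between compound 2 and compound 3 stayed within the scatter, whereas diethylcarbamoyl gives both a 3.8-fold higher number from compound 3 to compound 4 (0.58 log units; beyond the scatter) and a 2.7-fold higher number from compound 2 to compound 4 (0.43 log units; beyond the scatter) as steps beyond it. A separation beyond the scatter at this position therefore no longer depends on starting from the fluorine-bearing compound 1, although these two modest steps are much smaller than a 50-fold higher number from compound 1 to compound 4 (1.70 log units; beyond the scatter) and this last step is the widest listed among the four compounds. Nothing measured here accounts for the change, so the data give its size but not its origin.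

The compounds shown leave open whether the lead of compound 1 belongs to the fluorine atom itself or to the fluoromethyl group as a whole, which a hydroxymethyl or chloromethyl group on the same ring carbon would test. They also leave open whether the higher number of compound 4 follows the carbonyl on the ring carbon or the two ethyl chains, which a carboxylic acid or a dimethylcarbamoyl group there would help to separate.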